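Trimming a Methoxy Group: Toxicity Toward Vero Cells

A few compounds are considered here, and "the series" means these few. Any claim that something is new, unique, unknown or untested is made for them only; others in the source may bear on it.

Compound 1: `COc1ccc(-c2nc3cc(C(C)=O)ccc3[nH]2)c(OC)c1OC` – > 100000 nM
Compound 2: `O=C(CN1CCCCC1)Nc1ccc(-c2nc3cc(Cl)c(Cl)cc3[nH]2)cc1` – > 100000 nM
Compound 3: `O=[N+]([O-])c1ccc(-c2nc3cc(C(F)(F)F)ccc3n2C2CCCCC2)cc1` – > 100000 nM

In an ADME assay on Vero cells (Chlorocebus sabaeus) for cytotoxicity (on this read-out higher numbers stand for lower toxicity in this test and lower numbers for higher toxicity in this test), compound 1 gives > 100000 nM, which is a limit of the assay rather than a number. Compound 2 likewise reaches only the limit > 100000 nM. Compound 3 also sits at the limit with > 100000 nM. Compound 1 therefore stands where every value shown stands: the limit of > 100000 nM in this assay, at which 3 of the 3 values shown sit.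

Compound 4, `COc1ccc(-c2nc3cc(C(C)=O)ccc3[nH]2)c(OC)c1`, differs from compound 1 by hydrogen in place of methoxy on an aromatic carbon. Within the data shown here, no measured pair of compounds here differs in one place, so nothing measured tells how such a change shifts this read-out. Only a small step is expected, a number no higher from compound 1 to compound 4 (the limit leaves the size open), in no direction beyond the scatter. Compound 4 is thus expected to give 100000 nM, between 50000 nM and 200000 nM, most likely again reported as a limit.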

Compound 4, half-maximal cytotoxic concentration: > 100000 nM
Compound 4: a limit, no number (the forecaster's own chance of this, stated with the estimate: 85%); the middle value sits exactly at the limit.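

Compound 1 and compound 4 both reach only a limit in this assay, so the step between them cannot be read: the limit of > 100000 nM in this assay, at which 4 of the 4 values shown sit.

The compounds shown leave open how far hydrogen in place of methoxy shifts the half-maximal cytotoxic concentration, and which structure would give a number rather than a limit.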